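Triazolyl benzophenones: varying the amine on the triazole methyl

The compounds below may be only part of what the source reports. "The series", "measured", "known", "first", "only" and "open" are said of these compounds alone.

Measured so far in a functional assay on the whole organism (strain CF-1) for inhibition, with Mus musculus as the target; on this read-out lower numbers stand for an effect already at smaller amounts and higher numbers for an effect only at larger amounts of compound:
compound 1, `NCC(=O)Nc1ccc(Cl)cc1C(=O)c1ccccc1`, 29 mg/kg
compound 2, `Cc1nnc(CN(C)C)n1-c1ccc(Cl)cc1C(=O)c1ccccc1`, 45 mg/kg
compound 3, `Cc1nnc(CN2CCCC2)n1-c1ccc(Cl)cc1C(=O)c1ccccc1`, 89 mg/kg

Compound 3 gives the highest of the three numbers in this assay. Its nearest neighbour is compound 2, separated by a step that is within the scatter; compound 1 lies furthest away, and that gap is beyond the scatter. For the measured compounds named here, the one step that changes the amine on the saturated chain carbon bound to an aromatic carbon is a 2.0-fold higher number from compound 2 to compound 3 (0.30 log units; within the scatter), which did not leave the scatter.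

Compound 4, `CNCc1nnc(C)n1-c1ccc(Cl)cc1C(=O)c1ccccc1`, is not yet measured. Relative to compound 3 the change is methylamino in place of pyrrolidin-1-yl on a saturated chain carbon bound to an aromatic carbon. The step from compound 2 to compound 3 is the only measured one that bears on this change, and it was small; compound 4 carries an amine with fewer heavy atoms than either, so the expectation is a modest move back toward the number of compound 2, not beyond the scatter with confidence. The estimated step is a 1.8-fold lower number from compound 3 to compound 4 (0.25 log units; within the scatter). In this assay compound 4 is expected to give 50 mg/kg, with a range from 25 mg/kg to 110 mg/kg.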

Compound 4, dose for half-maximal effect: 63 mg/kg
Estimate against measurement, compound 4: 1.3-fold (0.10 log units) below; the range from low to high includes it.
By their numbers in this assay, from the lowest: compounds 1, 2, 4 and 3 (each within the scatter of the next, the first and the last beyond it).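

In this assay, methylamino in place of pyrrolidin-1-yl on the saturated chain carbon bound to an aromatic carbon gives a 1.4-fold lower number from compound 3 to compound 4 (0.15 log units; within the scatter), and hydrogen in place of methyl on the amine nitrogen gives a 1.4-fold higher number from compound 2 to compound 4 (0.15 log units; within the scatter). Compound 4 thus adds a hydrogen-bond donor on the amine at this place, the first in the triazole compounds shown, and neither of its steps leaves the scatter, so the three amines remain unresolved here. Nothing measured on these compounds offers an explanation for these small steps.

On these data alone, whether an unsubstituted amino group or a larger ring such as morpholine or piperidine at this place would move the number beyond the scatter remains open. Also open, as far as these compounds go, is whether a plain methyl carrying no amine at all, or a longer chain between the amine and the triazole, would do so.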